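A few compounds are considered here, and "the series" means these few. Any claim that something is new, unique, unknown or untested is made for them only; others in the source may bear on it.

Of the compounds shown here, three have been tested in a functional assay on CCRF-CEM cells (Homo sapiens) for cytotoxicity; on this read-out higher numbers stand for lower toxicity in this test and lower numbers for higher toxicity in this test. Compound 1 `O=C1c2ccccc2N(COCc2ccccc2)S(=O)(=O)N1Cc1ccccc1` gives 25 ug/mL in this assay, and compound 2 `C#CCOCN1c2ccccc2C(=O)N(Cc2ccccc2)S1(=O)=O` gives 23 ug/mL. Compound 3 `C#CCOCN1C(=O)c2ccccc2NS1(=O)=O` gives > 200 ug/mL, which is a limit of the assay and not a number, namely (the limit of > 200 ug/mL in this assay, at which 1 of the 3 values shown sits). Compound 4 `O=C1c2ccccc2NS(=O)(=O)N1COCc1ccccc1` has not yet been measured.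

Compounds 1 and 2 differ in one place: phenyl in place of ethynyl on a saturated chain carbon bound to an oxygen on a saturated carbon. This step, a 1.1-fold higher number from compound 2 to compound 1 (0.04 log units; within the scatter), changed little. The cores of compound 3 and compound 2 differ in more than one place, and that difference is not broken down here. Compound 4 stands to compound 3 as compound 1 stands to compound 2: phenyl in place of ethynyl on a saturated chain carbon bound to an oxygen on a saturated carbon, the same change in the same place.

In this assay the step to compound 4 is expected to be about as small, a step that the limit leaves unreadable from compound 3 to compound 4, because the earlier step of a 1.1-fold higher number from compound 2 to compound 1 (0.04 log units; within the scatter) stayed within the scatter. Compound 3 itself is known only by > 200 ug/mL. Compound 4 is therefore expected to give 250 ug/mL, quite possibly again only a limit, within 120 ug/mL to 600 ug/mL.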

Compound 4, half-maximal cytotoxic concentration: 91 ug/mL
Compound 4: the middle estimate sits 2.7-fold (0.44 log units) above what was measured; the measured number lies below the stated range.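

On the core of compound 3, phenyl in place of ethynyl gives an at least 2.1-fold lower number from compound 3 to compound 4 (0.34 log units; beyond the scatter) in this assay, so on this core the change does leave a mark on the read-out. The value of compound 3, > 200 ug/mL, is a limit of the assay and not a number, so this step has a lower bound but no exact size. The result therefore shows that a small step on one core cannot simply be assumed on another, but it does not show that the change truly acts differently on the two cores: the same change on two cores in this assay, a 1.1-fold higher number (0.04 log units; within the scatter) from compound 2 to compound 1 and an at least 2.1-fold lower number (0.34 log units; beyond the scatter) from compound 3 to compound 4; the limit leaves it open whether they differ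

The compounds shown leave open how far this behaviour extends beyond the swap of propargyl for benzyl, since only these two groups appear in this place. A longer saturated chain or a chain ending in an amine in the same place, on each of the two cores, could show whether the change follows any wider trend.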